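Swapping the acetyl ester of compound 1 for a nitrobenzoate

The source may hold more compounds than are shown below. What is called first, only, known or untested is meant among the compounds shown, and "the series" means these compounds.

Compound 1, `CC(=O)OC/C1=C/C[C@](C)(CCC=C(C)C)/C=C/[C@@H](OC(=O)C=C(C)C)[C@](C)(O)/C=C/C1=O`: 2950 nM
Compound 2, `C=C1/C=C/C(=O)/C(CO)=C\C[C@](C)(CCC=C(C)C)/C=C/[C@H]1OC(=O)C=C(C)C`: 2810 nM

Two macrocyclic esters from the same series have been tested in a functional assay on HL-60 cells (Homo sapiens) for antiproliferative activity, read by MTT assay, with a stated time of 48 h; a higher number here means a weaker inhibitor, a lower number a stronger inhibitor. Compound 1 gives 2950 nM. Compound 2 is a related compound carrying a hydroxymethyl group and an exocyclic methylene in place of the acetoxymethyl and tertiary alcohol of compound 1. In the same assay compound 2 gives 2810 nM. The two values lie within the scatter of each other, so compound 1 sits at the top of the pair only in the arithmetic sense and nothing separates the two.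

Compound 3, `CC(C)=CCC[C@]1(C)/C=C/[C@@H](OC(=O)C=C(C)C)[C@](C)(O)/C=C/C(=O)/C(COC(=O)c2ccc([N+](=O)[O-])cc2)=C\C1`, has not been measured. It differs from compound 1 in one place: 4-nitrophenyl in place of methyl on a carbonyl carbon. Among the measured compounds shown here, no step between measured compounds is available to calibrate such a change in this assay, so a modest shift in either direction, or none beyond the scatter, would be unsurprising. The value expected for compound 3 is 2000 nM, within 500 nM to 8000 nM, corresponding to an expected step of a 1.5-fold lower number from compound 1 to compound 3 (0.17 log units; within the scatter).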

Compound 3, half-maximal inhibitory concentration: 830 nM
Compound 3: middle estimate off by 2.4-fold (0.38 log units), on the high side; low and high end bracket the measured number.
By their numbers in this assay, from the lowest: compound 3; then compounds 2 and 1 (each within the scatter of the next).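

In this assay the change from acetyl to (4-nitrophenyl)carbonyl moves the number beyond the scatter (a 3.6-fold lower number from compound 1 to compound 3 (0.55 log units; beyond the scatter)). Among the compounds shown here, this is the first step read at this position, and it shows that the place on a carbonyl carbon is not silent: a methyl can give way to a six-membered aromatic ring with the inhibitor growing stronger rather than being lost. No measurement given here accounts for the shift.

A single step cannot say whether the ring alone or the nitro group on it carries the shift. On these data alone, what a plain phenyl, a 4-aminophenyl or a longer chain such as butyl would give on the same carbonyl carbon remains open.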